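Swapping Thiophen-2-yl for Phenyl in a Weak Antiproliferative Pair

The compounds below may be only part of what the source reports. "The series", "measured", "known", "first", "only" and "open" are said of these compounds alone.

Compound 1, `Nc1c(C(=O)N/N=C/c2ccccc2)oc2nc(-c3ccccc3)cc(C(F)(F)F)c12`: 70000 nM
Compound 2, `Cc1ccc(/C=N/NC(=O)c2oc3nc(-c4cccs4)cc(C(F)(F)F)c3c2N)cc1`: 78000 nM

Both compounds were tested in an ADME assay on HEK293 cells (Homo sapiens) for antiproliferative activity, read by MTT assay; on this read-out higher numbers stand for weaker inhibition and lower numbers for stronger inhibition. Compound 1 gives 70000 nM, and compound 2 gives 78000 nM. Of the two numbers, compound 2 holds the highest, yet its gap to compound 1 lies within the usual scatter, so the two cannot be ordered and neither can be called the weaker.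

Compound 3, `Cc1ccc(/C=N/NC(=O)c2oc3nc(-c4ccccc4)cc(C(F)(F)F)c3c2N)cc1`, differs from compound 2 in one way: phenyl in place of thiophen-2-yl on an aromatic carbon. Compound 1 already carries phenyl at that position and sits close to compound 2 in number, so nothing in these two values suggests that the change moves the read-out beyond the scatter. The step expected in this assay is a 1.1-fold lower number from compound 2 to compound 3 (0.03 log units; within the scatter), which is no step beyond the scatter. Compound 3 is therefore estimated at 72000 nM, with a likely range from 40000 nM to 130000 nM.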

Compound 3, half-maximal inhibitory concentration: 69000 nM
For compound 3 the middle estimate is 1.0-fold (0.02 log units) above the measured one, and the stated range covers the measured number.
By their numbers in this assay, from the lowest: compounds 3, 1 and 2 (each within the scatter of the next).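

Compound 1 and compound 2 differ in two places, so they could not show what the ring at this position does on its own, whereas compound 3 separates the two changes. Phenyl in place of thiophen-2-yl, on the aromatic carbon next to the ring nitrogen, gives a 1.1-fold lower number from compound 2 to compound 3 (0.05 log units; within the scatter) in this assay and so leaves the two rings indistinguishable at this position. Methyl in place of hydrogen on an aromatic carbon gives a 1.0-fold lower number from compound 1 to compound 3 (0.01 log units; within the scatter) and so neither change alone moves the read-out beyond the scatter.

Going by these compounds, all three compounds carry an aromatic ring at this position, so it remains open whether an amine or a carboxylic acid there would shift the number in this assay at all. No measurement here offers an explanation for these results.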